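The compounds below may be only part of what the source reports. "The series", "measured", "known", "first", "only" and "open" are said of these compounds alone.

Compound 1 `CC(=O)/C=C1\C[C@H]2SC(C)(C)[C@H](C(=O)OC(c3ccccc3)c3ccccc3)N2C1=O` carries an acetyl group on its shared core. In a functional assay on OE19 cells (Homo sapiens) for cytotoxicity, read by MTT assay, with a stated time of 48 h (on this read-out higher numbers stand for weaker inhibition and lower numbers for stronger inhibition), compound 1 gives only a limit, > 100000 nM, and no number (the limit of > 100000 nM in this assay, at which 1 of the 2 values shown sits). Compound 2 `CC1(C)S[C@@H]2/C(=C\C(=O)c3ccc(C(F)(F)F)cc3)C(=O)N2[C@H]1C(=O)OC(c1ccccc1)c1ccccc1` gives 15600 nM in this assay. Compound 3 `CC1(C)S[C@@H]2C/C(=C\C(=O)c3ccccc3)C(=O)N2[C@H]1C(=O)OC(c1ccccc1)c1ccccc1` differs from compound 1 by phenyl in place of methyl on a carbonyl carbon. No step between two measured compounds is available here, so the direction must be read from the single number shown. Since compound 2 gives 15600 nM, compound 3 is expected to reach a measurable value near 30000 nM, within 8000 nM to 100000 nM. The expected step is an at least 3.3-fold lower number from compound 1 to compound 3 (0.52 log units; beyond the scatter).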

Compound 3, half-maximal inhibitory concentration: 73300 nM
Beside the measured number, compound 3's estimate is 2.4-fold (0.39 log units) below it; the range from low to high includes it.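

With phenyl in place of methyl on this carbonyl carbon, compound 3 gives a real number in this assay, 73300 nM, so this position can now be followed with a measured value. The change from acetyl to benzoyl is an at least 1.3-fold lower number from compound 1 to compound 3 (0.13 log units; that floor lies within the scatter). Compound 1 offers only a limit and not a number, so this step has a floor but no exact size: the limit of > 100000 nM in this assay, at which 1 of the 3 values shown sits.

From the compounds shown here alone, it remains open how a cyclohexyl group or a longer chain on this carbonyl carbon would read in this assay. Such groups would help show whether the aromatic ring itself matters.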